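Trading the Amide Chain for a Thioether on a Shared Core

The source may report more compounds than this note shows. Statements on the series, on what has been measured and on what is new or still open speak of the compounds shown alone.

Three measured compounds share one core and differ only in the chain hanging from it: compound 1 `N#CCCCc1c[nH]c2ccc(F)cc12`, compound 2 `NC(=O)CCCCc1c[nH]c2ccc(F)cc12` and compound 3 `CNC(=O)CCCc1c[nH]c2ccc(F)cc12`. In an assay on isolated protein for inhibition of Myeloperoxidase (Homo sapiens), read by ELISA, with a stated time of 5 min (a higher number here means a weaker inhibitor, a lower number a stronger inhibitor), compound 1 gives 72 nM, compound 2 gives 43 nM and compound 3 gives 95 nM. Compound 2 carries the lowest of the three numbers; the step of a 1.7-fold lower number from compound 1 to compound 2 (0.22 log units; within the scatter) stays within the scatter, while a 2.2-fold higher number from compound 2 to compound 3 (0.34 log units; beyond the scatter) edges beyond it, and a 1.3-fold higher number from compound 1 to compound 3 (0.12 log units; within the scatter) again stays within it. Compound 4 `CCSCCc1c[nH]c2ccc(F)cc12` differs from compound 2 by ethylsulfanyl in place of 2-carbamoylethyl on a saturated chain carbon, two bonds along the chain from an aromatic carbon. Among the compounds with values here, no measured step removes the amide or shortens the chain, so the three small steps are only loose guides, and a small shift is expected. Compound 4 is therefore estimated at 90 nM, ranging from 30 nM to 300 nM. That estimate implies a step of a 2.1-fold higher number from compound 2 to compound 4 (0.32 log units; beyond the scatter).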

Compound 4, half-maximal inhibitory concentration: > 100 nM
Compound 4 was reported as a limit; the forecaster's own chance of this, stated with the estimate: 5%; middle value at least 1.1-fold (0.04 log units) from the limit.
By their numbers in this assay, from the lowest: compounds 2, 1 and 3 (each within the scatter of the next, the first and the last beyond it). At a limit, above all of these: compound 4.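

Compound 4 is reported only as a limit: the limit of > 100 nM in this assay, at which 1 of the 4 values shown sits. Even so, ethylsulfanyl in place of 2-carbamoylethyl on a saturated chain carbon gives an at least 2.3-fold higher number from compound 2 to compound 4 (0.36 log units; beyond the scatter), so losing the amide chain here costs a real step from the best of the series. Against the other chains, the floors of an at least 1.0-fold higher number from compound 3 to compound 4 (0.02 log units; that floor lies within the scatter) and an at least 1.3-fold higher number from compound 1 to compound 4 (0.14 log units; that floor lies within the scatter) lie within the scatter, so compound 4 cannot be ranked against them. From the compounds shown here alone, how far its true number lies past the limit stays open. So does whether a carboxylic acid or an amine at the chain end would match compound 2.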